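The source may report more compounds than this note shows. Statements on the series, on what has been measured and on what is new or still open speak of the compounds shown alone.

Compound 1 `CC(NC(=O)C#Cc1ccc(NC(=O)Nc2cc(C(F)(F)F)ccc2Cl)cc1)c1ccccc1` and compound 2 `CC(NC(=O)C#Cc1ccc(NC(=O)Nc2ccc(Cl)c(C(F)(F)F)c2)cc1)c1ccccc1` share a core and differ only in the aryl group attached on one amide-type nitrogen. Both were tested in a functional assay on MX1 cells (Homo sapiens) for inhibition, read by MTT assay, with a stated time of 120 h; on this read-out lower numbers stand for stronger inhibition and higher numbers for weaker inhibition. In this assay compound 1 gives 16100 nM and compound 2 gives 12800 nM. The change from the first to the second is 4-chloro-3-(trifluoromethyl)phenyl in place of 2-chloro-5-(trifluoromethyl)phenyl on an amide-type nitrogen and it made a 1.3-fold lower number from compound 1 to compound 2 (0.10 log units; within the scatter), so the two compounds cannot be told apart on this read-out.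

Compound 3 `CC(NC(=O)/C=C/Oc1ccc(NC(=O)Nc2cc(C(F)(F)F)ccc2Cl)cc1)c1ccccc1` carries the same aryl group as compound 1 but on a different core, and the difference between the two cores is not broken down here. In this assay compound 3 gives 16100 nM, level with compound 1 at the digits given.

Compound 4 `CC(NC(=O)/C=C/Oc1ccc(NC(=O)Nc2ccc(Cl)c(C(F)(F)F)c2)cc1)c1ccccc1` has not yet been measured. It differs from compound 3 by 4-chloro-3-(trifluoromethyl)phenyl in place of 2-chloro-5-(trifluoromethyl)phenyl on an amide-type nitrogen, the same change that separates compound 1 from compound 2, made at the same kind of place. Compound 4 is therefore expected to show a step of a 1.2-fold lower number from compound 3 to compound 4 (0.09 log units; within the scatter) because the same change on the core of compound 1 made a 1.3-fold lower number from compound 1 to compound 2 (0.10 log units; within the scatter), a step inside the usual scatter. The expectation rests on a single pair, and on the observation that compound 3 and compound 1 sit level with the shared aryl group. Compound 4 is estimated to give 13000 nM in this assay, with a likely range from 6500 nM to 26000 nM.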

Compound 4, half-maximal inhibitory concentration: 13700 nM
The estimate for compound 4 lay 1.1-fold (0.02 log units) below the measured number, within the range that was stated.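

In this assay, putting 4-chloro-3-(trifluoromethyl)phenyl in place of 2-chloro-5-(trifluoromethyl)phenyl on the core of compound 3 gives a 1.2-fold lower number from compound 3 to compound 4 (0.07 log units; within the scatter), so on this core too the two aryl groups cannot be told apart. Set beside the earlier step on the core of compound 1, the result shows that this change carried from one core to the other without any detectable difference in its effect: the same change on two cores in this assay, a 1.3-fold lower number (0.10 log units; within the scatter) from compound 1 to compound 2 and a 1.2-fold lower number (0.07 log units; within the scatter) from compound 3 to compound 4, 1.1-fold (0.03 log units) apart, within the scatter of two such steps

This agreement is only between two steps that are both too small to read as real effects, so it shows that the swap did little on either core, not that a clear effect of a substitution would carry across these cores in the same way, and two cores cannot establish a rule for the wider series.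

From the compounds shown here alone, it remains open whether a methoxy group, an amine or a carboxylic acid in place of the trifluoromethyl group on this aryl ring would move the number beyond the scatter. Also open, going by these compounds, is whether the same aryl swap would stay this small on a core with a longer chain, where the two aryl groups might no longer match.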